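The source may hold more compounds than are shown below. What is called first, only, known or untested is meant among the compounds shown, and "the series" means these compounds.

Of the compounds shown here, two have been measured in a functional assay on MDA-MB-231 cells (Homo sapiens) for antiproliferative activity, read by CCK-8 assay, with a stated time of 48 h; a higher number here means a weaker inhibitor, a lower number a stronger inhibitor. Compound 1 `Cc1ccc(-c2[nH]c3ccccc3c2C2=C(Br)C(=O)C(Br)=C(Br)C2=O)cc1` gives 21.6 ug/mL. Compound 2 `Cc1[nH]c2ccccc2c1C1=C(Br)C(=O)C(c2c(-c3ccccc3)[nH]c3ccccc23)=C(Br)C1=O` gives 5.64 ug/mL, the lowest of the two numbers, while compound 1 sits a step higher, beyond the scatter. For the measured compounds named here, the two differ in more than one place, so no single step between them is set out; their numbers show only that compound 2 is the stronger inhibitor of the pair.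

Compound 3 `Cc1ccc(-c2[nH]c3ccccc3c2C2=C(Br)C(=O)C(c3c(C)[nH]c4ccccc34)=C(Br)C2=O)cc1` has not yet been measured. It differs from compound 2 in one place: methyl in place of hydrogen on an aromatic carbon. Nothing in the measured pair isolates this change, since compound 1 already carries a 4-methylphenyl group but also differs from compound 2 elsewhere. Going by the values given here, with no measured step of this kind to lean on, the step from compound 2 to compound 3 is expected to stay within the scatter, in either direction. The expected step is a 1.0-fold lower number from compound 2 to compound 3 (0.01 log units; within the scatter). Compound 3 is therefore estimated at 5.5 ug/mL, with a range from 2.5 ug/mL to 12 ug/mL.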

Compound 3, half-maximal inhibitory concentration: 6.67 ug/mL
For compound 3 the middle estimate is 1.2-fold (0.08 log units) below the measured one, within the range that was stated.
By their numbers in this assay, from the lowest: compounds 2 and 3 (each within the scatter of the next); then compound 1.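

In this assay, methyl in place of hydrogen on the six-membered aromatic ring, para to a large group, turns phenyl into 4-methylphenyl and gives a 1.2-fold higher number from compound 2 to compound 3 (0.07 log units; within the scatter), so this single added carbon leaves the two numbers indistinguishable in this assay. The other comparison concerns a different part of the molecule, where 2-methyl-1H-indol-3-yl stands in place of bromo on a double-bonded ring carbon and gives a 3.2-fold lower number from compound 1 to compound 3 (0.51 log units; beyond the scatter), a modest step but one that, unlike the methyl step, lies beyond the scatter. No measurement is available to explain the size of either step.

Methyl is the only group shown at the new position, so it remains open whether a longer chain such as ethyl, a methoxy group or an amine there would also leave the number in the same place. As far as these compounds go, the bromo exchange is likewise seen with only one replacement, so it remains open how a simple amine or a carboxylic acid at that ring carbon would compare with 2-methyl-1H-indol-3-yl.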